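A few compounds are considered here, and "the series" means these few. Any claim that something is new, unique, unknown or untested is made for them only; others in the source may bear on it.

Notes on the series. In an ADME assay on BJ cells (Homo sapiens) for cytotoxicity, read by CellTiter-Glo and resazurin assay, with a stated time of 72 h (a higher number here means that more compound is needed for the effect, a lower number that less compound is needed), compound 1 `CCOC(=O)CCCCCOc1cccc(CN(C(=O)c2ccc(-c3ccoc3)cc2)C(C)C)c1` gives > 26000 nM, which is a limit of the assay and not a number. Compound 2 `CCOC(=O)CCCCCOc1cccc(CN(C(=O)c2ccc(-c3ccc(C(C)=O)s3)cc2)C(C)C)c1`, with 5-acetylthiophen-2-yl in place of furan-3-yl on an aromatic carbon, gives > 26000 nM in this assay, likewise a limit and not a number. Compound 2 thus stands at the limit, where both shown values sit (the limit of > 26000 nM in this assay, at which 2 of the 2 values shown sit), and nothing in the numbers separates it from compound 1.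

Compound 3 `CCOC(=O)CCCCCOc1cccc(CN(C(=O)c2ccc(-c3cccc(OC)c3)cc2)C(C)C)c1` differs from compound 2 by 3-methoxyphenyl in place of 5-acetylthiophen-2-yl on an aromatic carbon. Among the compounds with values here, only one measured step touches this carbon, a step that the two limits leave unreadable from compound 1 to compound 2, and because both ends sit at the limit of > 26000 nM in this assay, at which 2 of the 2 values shown sit, it yields neither size nor direction. The substituent at this carbon has therefore already been exchanged once without either value leaving the limit (the limit of > 26000 nM in this assay, at which 2 of the 2 values shown sit). The expectation for compound 3 is accordingly a step that the limit leaves unreadable from compound 2 to compound 3 of no readable size, with the result most likely again reported as a limit. Compound 3 is estimated at 40000 nM in this assay, within 15000 nM to 120000 nM.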

Compound 3, half-maximal effective concentration: > 21000 nM
Compound 3 gave a limit, no number; the forecaster's own chance of this, stated with the estimate: 80%; the middle value does not contradict the limit.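

Within the data shown here, compound 1, compound 2 and compound 3 are all reported only as limits in this assay, so no step among them can be read, in size or in direction. The compounds shown leave open where the half-maximal effective concentration of each lies, and whether the exchange on this aromatic carbon changes it at all.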